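The source may report more compounds than this note shows. Statements on the series, on what has been measured and on what is new or still open speak of the compounds shown alone.

In a functional assay on A549 cells (Homo sapiens) for antiproliferative activity, read by MTT assay, with a stated time of 72 h (on this read-out lower numbers stand for stronger inhibition and higher numbers for weaker inhibition), compound 1 `COc1ccc(N2CCN(C(=S)SCc3ccc4nc(N)nc(N)c4c3)CC2)cc1` gives 1590 nM and compound 2 `Cc1ccc(N2CCN(C(=S)SCc3ccc4nc(N)nc(N)c4c3)CC2)c(C)c1` gives 3000 nM, two values within the scatter of each other. Compound 3 `Nc1nc(N)c2cc(CSC(=S)N3CCN(c4ccc(Cl)c(Cl)c4)CC3)ccc2n1` differs from compound 2 by 3,4-dichlorophenyl in place of 2,4-dimethylphenyl on an amine nitrogen in a ring, with 3,4-dichlorophenyl in place of 2,4-dimethylphenyl on an amine nitrogen in a ring. Going by the values given here, the only measured step at this place, a 1.9-fold higher number from compound 1 to compound 2 (0.28 log units; within the scatter), stays within the scatter and gives no direction, so no shift beyond the scatter is expected in this assay. The expected step is a 1.5-fold lower number from compound 2 to compound 3 (0.18 log units; within the scatter). Compound 3 is estimated at 2000 nM, with a range from 600 nM to 6000 nM.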

Compound 3, half-maximal inhibitory concentration: 2940 nM
Beside the measured number, compound 3's estimate is 1.5-fold (0.17 log units) below it, within the range that was stated.
By their numbers in this assay, from the lowest: compounds 1, 3 and 2 (each within the scatter of the next).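

At the place on the amine nitrogen of the six-membered ring, 3,4-dichlorophenyl gives a 1.0-fold lower number from compound 2 to compound 3 (0.01 log units; within the scatter) and a 1.8-fold higher number from compound 1 to compound 3 (0.27 log units; within the scatter), so all three aryl groups now lie within the scatter of one another. Two chlorine atoms in place of two methyl groups or of one methoxy group therefore produce no readable shift here. Nothing available explains this flat result.

Still open, as far as these compounds go, is whether a phenyl ring carrying an amine or a carboxylic acid, or a cyclohexyl group on that nitrogen, would move the number beyond the scatter.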